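The source may hold more compounds than are shown below. What is called first, only, known or untested is meant among the compounds shown, and "the series" means these compounds.

Measured so far in an assay on isolated protein for displacement of a labelled ligand from Vasopressin V2 receptor (Rattus norvegicus); a higher number here means a weaker inhibitor, a lower number a stronger inhibitor:
Compound 1, `Cc1ccccc1N1CCN(S(=O)(=O)C[C@]23CCC(C[C@@H]2NC(=O)[C@H](CCS(C)(=O)=O)NC2CCNCC2)C3(C)C)CC1`, gives 130 nM.
Compound 2, `Cc1ccccc1N1CCN(S(=O)(=O)C[C@]23CCC(C[C@@H]2NC(=O)[C@H](CCS(C)(=O)=O)N(C)C)C3(C)C)CC1`, gives 290 nM.

Among the measured compounds shown here, of these two numbers compound 2 has the higher one, the only neighbour being compound 1 with a 2.2-fold higher number from compound 1 to compound 2 (0.35 log units; beyond the scatter), a change that touched the same position now under study. Compound 3, `Cc1ccccc1N1CCN(S(=O)(=O)C[C@]23CCC(C[C@@H]2NC(=O)[C@H](CCS(C)(=O)=O)N(CO)CO)C3(C)C)CC1`, differs from compound 2 by bis(hydroxymethyl)amino in place of dimethylamino on a saturated chain carbon bound to a carbonyl carbon and a saturated chain carbon. For the measured compounds named here, no measured pair shows this particular exchange, so only the modest size of that earlier step offers a scale. Compound 3 is therefore expected to stay close to compound 2 in this assay, with a step of a 1.2-fold lower number from compound 2 to compound 3 (0.06 log units; within the scatter) and an estimated value of 250 nM, between 100 nM and 650 nM.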

Compound 3, half-maximal inhibitory concentration: 240 nM
Beside the measured number, compound 3's estimate is 1.0-fold (0.02 log units) above it; measured number inside the range.
By their numbers in this assay, from the lowest: compounds 1, 3 and 2 (each within the scatter of the next, the first and the last beyond it).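

In this assay putting bis(hydroxymethyl)amino in place of dimethylamino gives a 1.2-fold lower number from compound 2 to compound 3 (0.08 log units; within the scatter) even though the group entering has 5 heavy atoms against 3 and 2 hydrogen-bond donors against 0, so this position tolerates that exchange. The comparison with (piperidin-4-yl)amino gives a 1.8-fold higher number from compound 1 to compound 3 (0.27 log units; within the scatter) and so cannot separate bis(hydroxymethyl)amino from that group either. Nothing available explains this tolerance. Still open, going by these compounds, is how a carboxylic acid or a primary amine on a longer chain would fare at this position.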